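Series notes: propyl to methylsulfanyl on compound 3

This account rests on a few compounds, and the source may have more. Where it says the series, first, only, none or still open, it means among the compounds named here.

Compound 3 `CCCc1ccc(C2NC(=S)NC(C)=C2C(=O)OCC)cc1` gives 42.4 ug/mL in a functional assay on PC-3 cells (Homo sapiens) for inhibition, read by sulforhodamine B assay, with a stated time of 48 h (a lower number here means a stronger inhibitor of growth, a higher number a weaker inhibitor of growth), the second highest number of the three measured; compound 1 `CCOC(=O)C1=C(C)NC(=S)NC1c1ccc(O)cc1` gives 47.6 ug/mL and compound 2 `CCOC(=O)C1=C(C)NC(=S)NC1c1ccc(F)cc1` gives 1.7 ug/mL. Compound 4 `CCOC(=O)C1=C(C)NC(=S)NC1c1ccc(SC)cc1` differs from compound 3 by methylsulfanyl in place of propyl on an aromatic carbon. Going by the values given here, the steps that bear on this position are a 1.1-fold lower number from compound 1 to compound 3 (0.05 log units; within the scatter) and a 25-fold higher number from compound 2 to compound 3 (1.40 log units; beyond the scatter); no measured compound carries methylsulfanyl there, so a direct guide is lacking. Only the fluoro member stands apart, while hydroxy and propyl sit together. The step of a 1.4-fold lower number from compound 3 to compound 4 (0.15 log units; within the scatter) is therefore expected to be small, though the uncertainty is wide. For compound 4 the estimate in this assay is 30 ug/mL, between 8 ug/mL and 80 ug/mL.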

Compound 4, concentration for 50% growth inhibition: 23.6 ug/mL
Beside the measured number, compound 4's estimate is 1.3-fold (0.10 log units) above it, within the range that was stated.
By their numbers in this assay, from the lowest: compound 2; then compounds 4, 3 and 1 (each within the scatter of the next).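

In this assay methylsulfanyl joins hydroxy and propyl as a third group that stays apart from fluoro: a 1.8-fold lower number from compound 3 to compound 4 (0.25 log units; within the scatter) and a 2.0-fold lower number from compound 1 to compound 4 (0.30 log units; within the scatter) are both small, whereas a 14-fold higher number from compound 2 to compound 4 (1.14 log units; beyond the scatter) is large. Among these four compounds, only compound 2 stands apart, and a sulfur-bearing group at this place does not reproduce its result. Nothing measured here accounts for the gap between fluoro and the other three groups.

As far as these compounds go, whether chloro, another halogen, would sit with fluoro or with the other three remains open. The same question stands for a methoxy group or an amine at this place.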